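The source may report more compounds than this note shows. Statements on the series, on what has been measured and on what is new or still open speak of the compounds shown alone.

Measured so far in a functional assay on HeLa cells (Homo sapiens) for inhibition, read by MTT assay, with a stated time of 24 h; a higher number here means a weaker inhibitor, a lower number a stronger inhibitor: compound 1 `CCOC(=O)C1=Cc2ccccc2OC1(OCc1cn(-c2ccc(C)cc2)nn1)C(F)(F)F` gives 25100 nM. Compound 2 `CCCCCCCCn1cc(COC2(C(F)(F)F)Oc3ccccc3C=C2C(=O)OCC)nn1` reaches only a limit of the assay, > 150000 nM. Compound 3 `CCOC(=O)C1=Cc2ccccc2OC1(OCc1cn(CC(=O)Nc2cccc(Cl)c2)nn1)C(F)(F)F` gives 12300 nM.

Compound 3 gives the lower of the two numbers; the gap between the two is a 2.0-fold lower number from compound 1 to compound 3 (0.31 log units; beyond the scatter). Compound 4 `CCOC(=O)C1=Cc2ccccc2OC1(OCc1cn(CC(=O)Nc2ccc(OC)cc2)nn1)C(F)(F)F` differs from compound 3 as follows: 4-methoxyphenyl in place of 3-chlorophenyl on an amide-type nitrogen. Going by the values given here, no measured step changes the aryl on the amide-type nitrogen; the steps of an at least 5.9-fold higher number from compound 1 to compound 2 (0.77 log units; beyond the scatter) and an at least 12-fold lower number from compound 2 to compound 3 (1.08 log units; beyond the scatter) vary the group on the aromatic nitrogen, and both involve (the limit of > 150000 nM in this assay, at which 1 of the 3 values shown sits). They therefore do not bear directly on the exchange in compound 4. The step of a 1.2-fold higher number from compound 3 to compound 4 (0.09 log units; within the scatter) is expected to lie within the scatter. Compound 4 is estimated at 15000 nM, with a range from 6000 nM to 40000 nM.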

Compound 4, half-maximal inhibitory concentration: 31900 nM
The estimate for compound 4 lay 2.1-fold (0.33 log units) below the measured number; the measured number falls inside the stated range.
By their numbers in this assay, from the lowest: compound 3; then compounds 1 and 4 (each within the scatter of the next). At a limit, above all of these: compound 2.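

The aryl on the amide-type nitrogen is not neutral: 4-methoxyphenyl in place of 3-chlorophenyl gives a 2.6-fold higher number from compound 3 to compound 4 (0.41 log units; beyond the scatter). The lower number seen for compound 3 relative to compound 1 is not kept with 4-methoxyphenyl: a 1.3-fold higher number from compound 1 to compound 4 (0.10 log units; within the scatter). The remaining step, an at least 4.7-fold lower number from compound 2 to compound 4 (0.67 log units; beyond the scatter), is only a bound, since one end is a limit of the assay: the limit of > 150000 nM in this assay, at which 1 of the 4 values shown sits.

Both the ring substituent and its ring position change in this exchange, so the two stay unseparated. Unsubstituted phenyl, 4-chlorophenyl, 3-methoxyphenyl or a carboxylic acid on that ring would address this.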